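Dimethylphenyl in place of methoxyphenyl on the biaryl

A few compounds are considered here, and "the series" means these few. Any claim that something is new, unique, unknown or untested is made for them only; others in the source may bear on it.

Measured compounds:
compound 1, `COc1ccccc1-c1cccc(COc2ccc([C@H](CC(=O)O)c3nccn3C)cc2)c1`, 410 nM
compound 2, `Cc1ccc(F)cc1-c1cccc(COc2ccc([C@H](CC(=O)O)c3nccn3C)cc2)c1`, 36 nM
compound 3, `COc1ccc(-c2cccc(COc3ccc([C@H](CC(=O)O)c4nccn4C)cc3)c2)cc1`, 440 nM

In an assay on CHO cells for agonist activity at Free fatty acid receptor 1 (Homo sapiens), read by luminescence, with a stated time of 20 s, in the presence of a further agent that is not named here (a lower number here means that less compound is needed, a higher number that more compound is needed for the effect), compound 3 gives the highest of the three numbers; compound 1 sits within the scatter of it, a 1.1-fold higher number from compound 1 to compound 3 (0.03 log units; within the scatter), while compound 2 lies well away, a 12-fold higher number from compound 2 to compound 3 (1.09 log units; beyond the scatter). The unmeasured compound 4, `Cc1cccc(C)c1-c1cccc(COc2ccc([C@H](CC(=O)O)c3nccn3C)cc2)c1`, differs from compound 3 by the change (2,6-dimethylphenyl in place of 4-methoxyphenyl on an aromatic carbon). Within the data shown here, two measured steps bear on it, both swapping a methoxy-bearing phenyl against a methyl-bearing one: an 11-fold lower number from compound 1 to compound 2 (1.06 log units; beyond the scatter) and the reverse of a 12-fold higher number from compound 2 to compound 3 (1.09 log units; beyond the scatter). Both were large and beyond the scatter, and both favoured the methyl-bearing ring. Among the measured compounds shown here, compound 4 carries two methyl groups and no methoxy, so a step of similar direction is expected, though compound 4 is not compound 2 and the second methyl has no measured precedent. The expected step is a 7.3-fold lower number from compound 3 to compound 4 (0.87 log units; beyond the scatter), a lower number beyond the scatter. For compound 4 the estimate in this assay is 60 nM, with a range from 18 nM to 250 nM.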

Compound 4, half-maximal effective concentration: 58 nM
Beside the measured number, compound 4's estimate is 1.0-fold (0.01 log units) above it; the range from low to high includes it.
By their numbers in this assay, from the lowest: compounds 2 and 4 (each within the scatter of the next); then compounds 1 and 3 (each within the scatter of the next).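

In this assay, the 2,6-dimethylphenyl ring separates from both methoxy-bearing rings, with a 7.6-fold lower number from compound 3 to compound 4 (0.88 log units; beyond the scatter) and a 7.1-fold lower number from compound 1 to compound 4 (0.85 log units; beyond the scatter). Against 5-fluoro-2-methylphenyl the result is a 1.6-fold higher number from compound 2 to compound 4 (0.21 log units; within the scatter), so across these four compounds the two methyl-bearing rings cannot be told apart, the fluorine is not required, and a second methyl is tolerated in place of it. Nothing in the data shown explains why the methyl-bearing rings and the methoxy-bearing rings fall into two groups.

As far as these compounds go, it remains open whether the methyl groups help or the methoxy group harms, a question that an unsubstituted phenyl ring would help to settle. From the compounds shown here alone, how a chlorine, a trifluoromethyl group or an amine on this ring would read also remains open.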